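Compound 2 to compound 3: a new aryl group

This account rests on a few compounds, and the source may have more. Where it says the series, first, only, none or still open, it means among the compounds named here.

In a functional assay on MDA-MB-231 cells (Homo sapiens) for antiproliferative activity, read by MTT assay, with a stated time of 72 h (a higher number here means a weaker inhibitor, a lower number a stronger inhibitor), compound 1 `CC1=CC[C@H]2[C@H](CC[C@]2(C)O)C(C)(C)[C@@H]1CC[C@H]1[C@]2(C)CC[C@H](OC(=O)c3ccccc3Cl)C(C)(C)O[C@H]2CC[C@@]1(C)O` gives 24300 nM and compound 2 `CC1=CC[C@H]2[C@H](CC[C@]2(C)O)C(C)(C)[C@@H]1CC[C@H]1[C@]2(C)CC[C@H](OC(=O)c3ccccc3C(F)(F)F)C(C)(C)O[C@H]2CC[C@@]1(C)O` gives 31500 nM. For the measured compounds named here, the only measured step is a 1.3-fold higher number from compound 1 to compound 2 (0.11 log units; within the scatter). On these numbers, compound 2 cannot be separated from compound 1.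

Compound 3 `CC1=CC[C@H]2[C@H](CC[C@]2(C)O)C(C)(C)[C@@H]1CC[C@H]1[C@]2(C)CC[C@H](OC(=O)c3ccc(C(F)(F)F)c(F)c3)C(C)(C)O[C@H]2CC[C@@]1(C)O` keeps the shared core but has 3-fluoro-4-(trifluoromethyl)phenyl in place of 2-(trifluoromethyl)phenyl on a carbonyl carbon. Going by the values given here, the measured step bears on this change only indirectly, as it exchanged one group on an aromatic carbon, and no measured compound carries the entering group. The data therefore give no direction for a shift in this assay, and a wide range is warranted. The expected size is no more than the scatter, at a 1.1-fold lower number from compound 2 to compound 3 (0.05 log units; within the scatter). Compound 3 is estimated at 28000 nM, with an expected range of 13000 nM to 60000 nM.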

Compound 3, half-maximal inhibitory concentration: 22200 nM
Estimate against measurement, compound 3: 1.3-fold (0.10 log units) above, within the range that was stated.
By their numbers in this assay, from the lowest: compounds 3, 1 and 2 (each within the scatter of the next).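

In this assay, 3-fluoro-4-(trifluoromethyl)phenyl in place of 2-(trifluoromethyl)phenyl on a carbonyl carbon gives a 1.4-fold lower number from compound 2 to compound 3 (0.15 log units; within the scatter) and in place of 2-chlorophenyl gives a 1.1-fold lower number from compound 1 to compound 3 (0.04 log units; within the scatter) as the second reading for the same entering group. For the compounds shown here, the earlier step exchanged only one group on an aromatic carbon, whereas these steps replace the whole aryl group, and the three compounds still cannot be separated at this position. The data offer nothing that would explain this lack of separation.

Open, from the compounds shown here alone, is whether an aryl group carrying an amine or a carboxylic acid would give a step beyond the scatter at this carbonyl carbon. Also open, going by these compounds, is whether a pyridine ring or a saturated alkyl chain in place of the aryl group would do so.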